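This account rests on a few compounds, and the source may have more. Where it says the series, first, only, none or still open, it means among the compounds named here.

Series notes on cytotoxicity. In a functional assay on MT4 cells (Homo sapiens) for cytotoxicity, read by MTT assay (a higher number here means that more compound is tolerated, a lower number that less compound is tolerated), compound 1 `COc1ccc(CSc2nc(O)c(C)c(Cc3ccc(F)cc3)n2)cc1` gives 8900 nM. Compound 2 `Cc1c(O)nc(SCc2ccc(Cl)cc2)nc1Cc1c(Cl)cccc1Cl` gives no number in this assay, only > 59000 nM, which is a limit of the assay. Compound 3 `Cc1c(O)nc(SCc2ccc(C(C)C)cc2)nc1Cc1c(F)cccc1F` likewise gives only a limit in this assay, > 62000 nM. On the numbers shown, compound 2 therefore stands at the limit of > 59000 nM in this assay, at which 1 of the 3 values shown sits, and of the three values one more is a limit rather than a number, (the limit of > 62000 nM in this assay, at which 1 of the 3 values shown sits). Going by the values given here, no pair of measured compounds differs in a single place, so the size that one exchange produces in this assay cannot be read from these three.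

Compound 4 `Cc1c(O)nc(SCc2ccc(Br)cc2)nc1Cc1c(Cl)cccc1Cl` is not yet measured in this assay. It differs from compound 2 in one place: bromo in place of chloro on an aromatic carbon. An exchange of this kind is expected to shift the reading by no more than the scatter, in either direction, so the expected step is a step that the limit leaves unreadable from compound 2 to compound 4. Compound 2 sits only at a limit in this assay. Compound 4 is accordingly expected at 60000 nM, with a range from 30000 nM to 120000 nM, and most probably it will again return only a limit rather than a number.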

Compound 4, half-maximal cytotoxic concentration: 13000 nM
Beside the measured number, compound 4's estimate is 4.6-fold (0.66 log units) above it; measured number below the stated range.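

Going by these compounds alone, the exchange of chloro for bromo, 4-chlorobenzyl to 4-bromobenzyl with the rest of compound 2 unchanged, gives the first single-place step in this assay, and it reads an at least 4.5-fold lower number from compound 2 to compound 4 (0.65 log units; beyond the scatter). This position on the aromatic ring therefore matters for the reading, and even a change between two single halogen atoms, with no ring, hydrogen-bond donor, hydrogen-bond acceptor or net charge entering or leaving, moves it beyond the scatter. Compound 2 carries a limit and not a number, so the true step may be larger than the printed one: the limit of > 59000 nM in this assay, at which 1 of the 4 values shown sits.

Compounds 1 and 3 each differ from compound 2 and compound 4 in more than one place, so the shown data cannot tell whether the same exchange would lower the reading on another benzyl group or with another substitution on the second aromatic ring. Nor do they show how this assay responds when the bromo is replaced by an amine, a carboxylic acid or a longer alkyl chain, or where plain hydrogen would fall relative to the two halogens.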